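A few compounds are considered here, and "the series" means these few. Any claim that something is new, unique, unknown or untested is made for them only; others in the source may bear on it.

Working notes on the series. The compounds share one core: compound 1 is `CCN(c1ccc(C#N)c(Cl)c1)c1cc(-c2cnc3ccccc3c2)ccc1C`, compound 2 is `CCN(c1ccc(C#N)c(Cl)c1)c1cc(-c2cncnc2)ccc1C`, compound 3 is `CCN(c1ccc(C#N)c(C(F)(F)F)c1)c1cc(-n2ccnc2)ccc1C`, and compound 4, not yet measured, is `CCN(c1ccc(C#N)c(Cl)c1)c1cc(-c2ccc(F)nc2)ccc1C`. All are judged in a functional assay on PC-3 cells (Homo sapiens) for antiproliferative activity, read by CCK-8 assay, with a stated time of 6 days; a higher number here means a weaker inhibitor, a lower number a stronger inhibitor. In this assay compound 1 gives 3570 nM. For compound 2 this assay returns only a limit, > 30000 nM, and not a number. For compound 3 this assay likewise returns only a limit, > 30000 nM. For the measured compounds named here, compound 2 therefore sits at the limit of > 30000 nM in this assay, at which 2 of the 3 values shown sit, so its own place on the scale is not fixed, and no step between two measured compounds is available to lean on; compound 1 alone supplies a number among the three. The change from compound 2 to compound 4 is 6-fluoropyridin-3-yl in place of pyrimidin-5-yl on an aromatic carbon. Going by the values given here, with no measured step to guide the direction, the expectation rests on the change itself: a step from compound 2 to compound 4 of an at least 3.0-fold lower number from compound 2 to compound 4 (0.47 log units; beyond the scatter) toward a stronger inhibitor in this assay is expected, with a fair chance that this assay again reports only a limit. Compound 4 is estimated at 10000 nM in this assay, with a range from 3000 nM to 30000 nM.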

Compound 4, half-maximal inhibitory concentration: > 30000 nM
Compound 4 gave a limit, no number; the forecaster's own chance of this, stated with the estimate: 30%; middle value at least 3.0-fold (0.47 log units) from the limit.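

In this assay compound 2 and compound 4 both return only a limit, so no step between them can be read: the limit of > 30000 nM in this assay, at which 3 of the 4 values shown sit.

The compounds shown leave open where compound 2 and compound 4 actually stand on the scale, and so how 6-fluoropyridin-3-yl compares with pyrimidin-5-yl on the shared core.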